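A Second Fluoro on the Weakest Member of a Small Series

The source may report more compounds than this note shows. Statements on the series, on what has been measured and on what is new or still open speak of the compounds shown alone.

Of the compounds shown here, three sharing one core have been measured in an assay on mitochondria from L6 cells (Rattus norvegicus) for activation, with a stated time of 90 min; a lower number here means that less compound is needed, a higher number that more compound is needed for the effect. Compound 1 `CCCCOc1cccc(Nc2nc3nonc3nc2O)c1` gives 2300 nM. Compound 2 `Oc1nc2nonc2nc1Nc1cccc(S(F)(F)(F)(F)F)c1` gives 3700 nM. Compound 3 `Oc1nc2nonc2nc1Nc1cccc(F)c1` gives 31200 nM, the highest number of the three: it stands an 8.4-fold higher number from compound 2 to compound 3 (0.93 log units; beyond the scatter) and a 14-fold higher number from compound 1 to compound 3 (1.13 log units; beyond the scatter). The step of a 1.6-fold higher number from compound 1 to compound 2 (0.21 log units; within the scatter) falls within the scatter, so compounds 1 and 2 cannot be ordered against each other.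

Compound 4 `Oc1nc2nonc2nc1Nc1cc(F)cc(F)c1` differs from compound 3 by one change, (fluoro in place of hydrogen on an aromatic carbon). Among the measured compounds shown here, only two of the measured steps touch on fluoro at all: the step from compound 1 to compound 3 and the step from compound 2 to compound 3, both large in the direction of a higher number when a bigger group gives way to a single fluoro. For the measured compounds named here, neither step adds a fluoro to a ring that already carries one, so no measured step bears directly on this change. The expectation is therefore a step of a 1.4-fold lower number from compound 3 to compound 4 (0.15 log units; within the scatter), kept small and treated as within the scatter. Compound 4 is expected to give 22000 nM, with a range from 7000 nM to 70000 nM.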

Compound 4, half-maximal effective concentration: 23400 nM
Estimate against measurement, compound 4: 1.1-fold (0.03 log units) below; low and high end bracket the measured number.
By their numbers in this assay, from the lowest: compounds 1 and 2 (each within the scatter of the next); then compounds 4 and 3 (each within the scatter of the next).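

In this assay, putting a fluoro in place of hydrogen on an aromatic carbon meta to a fluoro group gives a 1.3-fold lower number from compound 3 to compound 4 (0.12 log units; within the scatter), a step that stays within the scatter, so compound 3 and compound 4 cannot be ordered against each other. Among the compounds shown here, the earlier steps all exchanged one group for another on a single ring carbon, whereas this step is the first to fill a further ring carbon that carried only hydrogen, and at this position a fluoro brings no change that can be told apart from the ordinary spread of repeated measurements. No supporting measurement is available that could explain this result.

Whether an amine, a carboxylic acid or a longer chain on this same aromatic carbon would shift the number beyond the scatter remains open, since a fluoro is the only group shown there. From the compounds shown here alone, it is also open whether the same fluoro would leave the number just as little changed on compound 1, with its butoxy group, or on compound 2, with its group of 6 heavy atoms.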